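Replacing a ketone with a plain propyl chain on the core

The source may report more compounds than this note shows. Statements on the series, on what has been measured and on what is new or still open speak of the compounds shown alone.

Measured compounds:
compound 1 `O=c1sc2ccccc2n1CCCCN1CCCCCC1`: 3.2 nM
compound 2 `CCC(=O)c1ccc2c(c1)sc(=O)n2CCCCN1CCCCCC1`: 10.3 nM
compound 3 `CCCC(=O)c1ccc2c(c1)sc(=O)n2CCCCN1CCCCCC1`: 4.8 nM

In an assay on cell membranes for displacement of a labelled ligand from Sigma non-opioid intracellular receptor 1 (Rattus norvegicus) (a higher number here means a weaker inhibitor, a lower number a stronger inhibitor), compound 3 gives 4.8 nM, the second highest of the three numbers. Its nearest neighbour is compound 1 at 3.2 nM; the step of a 1.5-fold higher number from compound 1 to compound 3 (0.18 log units; within the scatter) lies within the scatter. Compound 2 stands furthest away, and the step of a 2.1-fold lower number from compound 2 to compound 3 (0.33 log units; beyond the scatter) is modest but beyond the scatter. The other measured step, a 3.2-fold higher number from compound 1 to compound 2 (0.51 log units; beyond the scatter), is also modest.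

Compound 4 `CCCc1ccc2c(c1)sc(=O)n2CCCCN1CCCCCC1` differs from compound 3 by propyl in place of propylcarbonyl on an aromatic carbon. Going by the values given here, no measured step removes a carbonyl from this position, so none bears directly on the change. What the data show is that the substituent at this aromatic carbon hardly moved the number between compound 1 and compound 3, while a longer chain rather than a shorter one gave the lower number in this assay. On that basis compound 4 is expected to stay close to compound 3, with a step of a 1.2-fold lower number from compound 3 to compound 4 (0.08 log units; within the scatter) that may well fall within the scatter. The estimate for compound 4 in this assay is 4 nM, with a range from 1.5 nM to 12 nM.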

Compound 4, inhibition constant: 6.1 nM
Beside the measured number, compound 4's estimate is 1.5-fold (0.18 log units) below it; the range from low to high includes it.
By their numbers in this assay, from the lowest: compounds 1, 3, 4 and 2 (each within the scatter of the next, the first and the last beyond it).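

In this assay the carbonyl of the propylcarbonyl group makes no difference that can be read at this aromatic carbon, since the swap to propyl gives a 1.3-fold higher number from compound 3 to compound 4 (0.10 log units; within the scatter). The propyl chain can also be set against propanoyl and against hydrogen at the same carbon, with a 1.7-fold lower number from compound 2 to compound 4 (0.23 log units; within the scatter) and with a 1.9-fold higher number from compound 1 to compound 4 (0.28 log units; within the scatter), so neither comparison separates it. Going by these compounds alone, the only steps at this position beyond the scatter therefore remain the two that involve compound 2, and that gap does not extend to compound 4.

Nothing at hand gives a reason for these numbers. The compounds shown leave open how this aromatic carbon responds to a different kind of group, such as an amine or a carboxylic acid, or to a longer chain such as hexyl.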